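Swapping a Hydroxy Tetralin for Isoquinoline on a Urea

The source may report more compounds than this note shows. Statements on the series, on what has been measured and on what is new or still open speak of the compounds shown alone.

Two measured compounds share one core and differ only in the group on one urea nitrogen. In an assay on CHO cells for displacement of a labelled ligand from transient receptor potential cation channel subfamily V member 1 (Homo sapiens), read by scintillation counting, with a stated time of 60 min (on this read-out lower numbers stand for stronger inhibition and higher numbers for weaker inhibition), compound 1 `CN(C)C1(Cc2ccccc2)CCN(c2cc(C(F)(F)F)ccc2CNC(=O)Nc2ccc(CNS(C)(=O)=O)c(F)c2)CC1` gives 16.4 nM, while compound 2 `CN(C)C1(Cc2ccccc2)CCN(c2cc(C(F)(F)F)ccc2CNC(=O)Nc2cccc3c2CC(O)CC3)CC1` gives 0.95 nM, the lowest of the two numbers and beyond the scatter from compound 1. Compound 3 `CN(C)C1(Cc2ccccc2)CCN(c2cc(C(F)(F)F)ccc2CNC(=O)Nc2ccc3ccncc3c2)CC1` carries isoquinolin-7-yl in place of 3-hydroxy-1,2,3,4-tetrahydronaphthalen-5-yl on an amide-type nitrogen. Within the data shown here, no measured pair covers this change, so the step is judged from the change alone: the expected step is a 5.3-fold higher number from compound 2 to compound 3 (0.72 log units; beyond the scatter), a modest weakening in this assay. Compound 3 is therefore estimated at 5 nM, with a range from 1 nM to 30 nM.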

Compound 3, inhibition constant: 7.33 nM
The estimate for compound 3 lay 1.5-fold (0.17 log units) below the measured number; low and high end bracket the measured number.
By their numbers in this assay, from the lowest: compound 2; then compound 3; then compound 1.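

On this amide-type nitrogen, isoquinolin-7-yl can stand in for 3-hydroxy-1,2,3,4-tetrahydronaphthalen-5-yl at a modest cost: in this assay the change gives a 7.7-fold higher number from compound 2 to compound 3 (0.89 log units; beyond the scatter) and leaves compound 3 at 7.33 nM in the low nanomolar range. The group that enters has no hydrogen-bond donor, while the group that leaves has one, and both rings of the group change as well. Nothing measured here explains the step.

Going by these compounds, it remains open whether the lost hydroxy group or the altered ring system matters more. An amine in place of that hydroxy group would test only the first.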